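Removing the 1-hydroxyethyl group from compound 2

The compounds below may be only part of what the source reports. "The series", "measured", "known", "first", "only" and "open" are said of these compounds alone.

In an ADME assay on KB cells (Homo sapiens) for cytotoxicity, with a stated time of 48 h (a higher number here means a weaker inhibitor, a lower number a stronger inhibitor), compound 1 `CC1=CCC[C@](C)(CC/C(C)=C/CC2=C(O)C(=O)C=C(N[C@H](C(=O)O)[C@H](C)O)C2=O)[C@@H]1C` gives > 10 ug/mL, which is a limit of the assay and not a number. Compound 2 `CC1=CCC[C@](C)(CC/C(C)=C/CC2=C(O)C(=O)C=C(N[C@@H](C(=O)O)[C@H](C)O)C2=O)[C@@H]1C` gives > 10 ug/mL, again only a limit. Compound 3 `CC1=CCC[C@](C)(CC/C(C)=C/CC2=C(O)C(=O)C=C(NCC(=O)O)C2=O)[C@@H]1C` differs from compound 2 by hydrogen in place of 1-hydroxyethyl on a saturated chain carbon bound to an amine nitrogen and a carbonyl carbon, the change lying on a saturated chain carbon bound to an amine nitrogen and a carbonyl carbon. Among the compounds with values here, the only measured step, a step that the two limits leave unreadable from compound 1 to compound 2, changes configuration alone and gives no size to build on, so no clear shift in either direction is expected. The expected step is a step that the limit leaves unreadable from compound 2 to compound 3. For compound 3 the estimate is 15 ug/mL, with an expected range from 6 ug/mL to 40 ug/mL.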

Compound 3, half-maximal inhibitory concentration: 5.4 ug/mL
Compound 3: the middle estimate sits 2.8-fold (0.44 log units) above what was measured; the measured number lies below the stated range.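

Within the data shown here, compound 3, with hydrogen in place of 1-hydroxyethyl, is the first compound to give an actual number in this assay: 5.4 ug/mL. The change gives an at least 1.8-fold lower number from compound 2 to compound 3 (0.26 log units; that floor lies within the scatter), and likewise an at least 1.8-fold lower number from compound 1 to compound 3 (0.26 log units; that floor lies within the scatter). These steps are only floors, so the true size of the change cannot be read, because of how the other values stand: the limit of > 10 ug/mL in this assay, at which 2 of the 3 values shown sit.

Going by these compounds, it remains open what a methyl or a hydroxymethyl group would give on this saturated chain carbon. Such groups could show whether any substituent here raises the number, or only 1-hydroxyethyl.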